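From a Dimethylphenyl Amide to a Dichlorophenyl Urea

The source may report more compounds than this note shows. Statements on the series, on what has been measured and on what is new or still open speak of the compounds shown alone.

Compound 1 `CCCCCCCC/C=C\CCCCCCCCNC(=O)Nc1c(OC)cc(OC)cc1OC`: 320 nM
Compound 2 `CCCCCCCC/C=C\CCCCCCCCNC(=O)c1c(C)cccc1C`: 9800 nM
Compound 3 `CCCCCCCCCCCCCCCCCCSc1c(C)cccc1C`: > 10000 nM

All three measured compounds were tested in an assay on microsomes from intestinal mucosa for inhibition of acyl-CoA:cholesterol acyltransferase (Oryctolagus cuniculus); a higher number here means a weaker inhibitor, a lower number a stronger inhibitor. Compound 2 has the highest of the two numbers actually read out; its nearest neighbour is compound 1, whose number is lower by a margin well beyond the usual scatter of this assay. Compound 3 sits at the limit of > 10000 nM in this assay, at which 1 of the 3 values shown sits, which is a limit of the assay and not a number.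

Compound 4 `CCCCCCCC/C=C\CCCCCCCCNC(=O)Nc1c(Cl)cccc1Cl` has not yet been measured. It differs from compound 2 in one place: (2,6-dichlorophenyl)amino in place of 2,6-dimethylphenyl on a carbonyl carbon. Among the measured compounds shown here, no pair of measured compounds differs in exactly this way, so no measured step shows how large the effect of this change should be. For the measured compounds named here, the only guide is compound 1, the other urea in the set, which gives 320 nM in this assay. On that basis the number for compound 4 is expected to move toward the stronger end rather than stay where compound 2 sits. Compound 4 is estimated at 1500 nM, with a likely range from 300 nM to 7000 nM. The expected step of a 6.5-fold lower number from compound 2 to compound 4 (0.82 log units; beyond the scatter) would be a clear move to a lower number, though the range remains wide.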

Compound 4, half-maximal inhibitory concentration: 400 nM
Estimate against measurement, compound 4: 3.8-fold (0.57 log units) above, and the stated range covers the measured number.
By their numbers in this assay, from the lowest: compounds 1 and 4 (each within the scatter of the next); then compound 2. At a limit, above all of these: compound 3.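

In this assay, among the compounds shown here, replacing 2,6-dimethylphenyl with (2,6-dichlorophenyl)amino on a carbonyl carbon gives a 25-fold lower number from compound 2 to compound 4 (1.39 log units; beyond the scatter) and is the first change in a single place that can be read in this set. For the compounds shown here, until this result, no two measured compounds differed in only one place, so the effect of any single change was unknown; this step shows that the group on the carbonyl carbon can strongly change the measured inhibition while the long chain stays the same. The swap alters two things at once, bringing in a nitrogen with a hydrogen-bond donor and exchanging methyl groups for chlorines on the ring, and nothing measured here explains the step or shows which of the two alterations accounts for it.

The compounds shown leave open how much of the step belongs to the nitrogen and how much to the chlorines, a question that a 2,6-dichlorophenyl amide or a 2,6-dimethylphenyl urea could settle. They also leave open what a single chlorine, a fluorine or a carboxylic acid on the ring, or a shorter chain, would do to the inhibition.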